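Removing the fluoro group from compound 2

A few compounds are considered here, and "the series" means these few. Any claim that something is new, unique, unknown or untested is made for them only; others in the source may bear on it.

Among the compounds with values here, in a functional assay on A549 cells (Homo sapiens) for cytotoxicity, read by MTT assay, with a stated time of 72 h (on this read-out higher numbers stand for weaker inhibition and lower numbers for stronger inhibition), compound 2 `CNC(=O)c1cc(Oc2ccc(NC(=O)c3nccc(-c4ccc(OC)cc4)n3)cc2F)ccn1` gives 16600 nM, the only actual number so far. Compound 1 `CNC(=O)c1cc(Oc2ccc(NC(=O)c3nccc(-c4cccc(Cl)c4)n3)cc2)ccn1` returns only a limit of this assay, > 100000 nM. Compound 3 `CNC(=O)c1cc(Oc2ccc(NC(=O)c3nccc(-c4ccc(OC)cc4)n3)cc2)ccn1` carries hydrogen in place of fluoro on an aromatic carbon, ortho to a (2-(methylcarbamoyl)pyridin-4-yl)oxy group (hydrogen in place of fluoro on an aromatic carbon). Within the data shown here, no measured pair isolates this change, so the expectation rests on the value of compound 2 alone, 16600 nM. The estimated step of a 1.3-fold higher number from compound 2 to compound 3 (0.12 log units; within the scatter) stays within the scatter of this assay. For compound 3 the expected value is 22000 nM, with an estimated range of 8000 nM to 70000 nM.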

Compound 3, half-maximal inhibitory concentration: 11100 nM
Compound 3: the middle estimate sits 2.0-fold (0.30 log units) above what was measured; the range from low to high includes it.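

Replacing fluoro with hydrogen on this aromatic carbon, ortho to a (2-(methylcarbamoyl)pyridin-4-yl)oxy group, gives a 1.5-fold lower number from compound 2 to compound 3 (0.17 log units; within the scatter), so in this assay the two compounds cannot be told apart. Replacing 3-chlorophenyl with 4-methoxyphenyl gives a clearer separation, an at least 9.0-fold lower number from compound 1 to compound 3 (0.95 log units; beyond the scatter). The size of that step stays open-ended, since compound 1 gives only a limit of the assay: the limit of > 100000 nM in this assay, at which 1 of the 3 values shown sits.

Still open, going by these compounds, is whether a methoxy group or an amine on the fluoro-bearing carbon would give a step beyond the scatter. Also open, on these data alone, is how an amine or a carboxylic acid on the phenyl ring would compare with 4-methoxyphenyl.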